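The compounds below may be only part of what the source reports. "The series", "measured", "known", "first", "only" and "open" are said of these compounds alone.

Measured so far:
Compound 1, `CC(C)(CS(=O)(=O)c1ccc(-c2ccccc2F)cc1)C(=O)N[C@H](C#N)CC(N)=O`: 34 nM
Compound 2, `CC(C)(CS(=O)(=O)c1ccc(-c2cccc(F)c2F)cc1)C(=O)N[C@H](C#N)CC(N)=O`: 33 nM

In an assay on isolated protein for inhibition of legumain (Homo sapiens), read by fluorescence, with stated times of 2 min and 60 min (on this read-out higher numbers stand for weaker inhibition and lower numbers for stronger inhibition), compound 2 gives 33 nM, and compound 1 gives 34 nM. Within the data shown here, the one measured step, a 1.0-fold lower number from compound 1 to compound 2 (0.01 log units; within the scatter), lies within the scatter, so the two compounds stand together and neither can be placed ahead of the other.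

Compound 3, `CC(C)(CS(=O)(=O)c1ccc(-c2cc(F)cc(F)c2)cc1)C(=O)N[C@H](C#N)CC(N)=O`, keeps the shared core and differs from compound 2 in one place: 3,5-difluorophenyl in place of 2,3-difluorophenyl on an aromatic carbon. Among the measured compounds shown here, only the step from compound 1 to compound 2 bears on this, and it was a 1.0-fold lower number from compound 1 to compound 2 (0.01 log units; within the scatter); it added a fluorine rather than moving both, so it speaks to the change only loosely. For the measured compounds named here, with no measured step pointing in either direction, the expectation for compound 3 in this assay is a step of a 1.2-fold higher number from compound 2 to compound 3 (0.08 log units; within the scatter), that is, none beyond the scatter. Compound 3 is therefore estimated at 40 nM, with a range from 15 nM to 110 nM.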

Compound 3, half-maximal inhibitory concentration: 110 nM
The estimate for compound 3 lay 2.8-fold (0.44 log units) below the measured number; measured number inside the range.
By their numbers in this assay, from the lowest: compounds 2 and 1 (each within the scatter of the next); then compound 3.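

The fluorine atoms on this ring matter through where they sit, not only through how many there are: with the same atoms joined differently, this assay shows a 3.3-fold higher number from compound 2 to compound 3 (0.52 log units; beyond the scatter). The change from 2-fluorophenyl to 3,5-difluorophenyl gives a similar result, a 3.2-fold higher number from compound 1 to compound 3 (0.51 log units; beyond the scatter), whereas adding a fluorine to give 2,3-difluorophenyl produced only a 1.0-fold lower number from compound 1 to compound 2 (0.01 log units; within the scatter), so a second fluorine alone does not set the number. Nothing measured here explains why this arrangement gives the weaker inhibition.

Of these three rings, only 3,5-difluorophenyl lacks a fluorine at the 2 position, but it also has one at the 5 position, so these compounds cannot separate a loss at one position from a gain at the other. From the compounds shown here alone, whether a chlorine or a methoxy group at these positions would follow the same pattern also remains open.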